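Chloro added to a urea aryl of compound 1

The compounds below may be only part of what the source reports. "The series", "measured", "known", "first", "only" and "open" are said of these compounds alone.

Compound 1 `O=C(Nc1cccc(-n2cc(-c3ccncc3)c(-c3ccc(Cl)c(O)c3)n2)c1)Nc1cccc(C(F)(F)F)c1` and compound 2 `COc1cc(-c2nn(-c3cccc(NC(=O)Nc4cccc(C(F)(F)F)c4)c3)cc2-c2ccncc2)ccc1Cl` share one core. In a functional assay on T47D cells (Homo sapiens) for inhibition, read by sulforhodamine B assay, with a stated time of 48 h (a lower number here means a stronger inhibitor of growth, a higher number a weaker inhibitor of growth), compound 1 gives 2470 nM, the higher of the two numbers; compound 2 gives 1650 nM, and the step of a 1.5-fold lower number from compound 1 to compound 2 (0.18 log units; within the scatter) is methyl in place of hydrogen on an oxygen on an aromatic ring. Compound 3 `O=C(Nc1cccc(-n2cc(-c3ccncc3)c(-c3ccc(Cl)c(O)c3)n2)c1)Nc1ccc(Cl)c(C(F)(F)F)c1` differs from compound 1 by chloro in place of hydrogen on an aromatic carbon. For the measured compounds named here, no measured step touches this place, so nothing here argues for a change beyond the scatter. Compound 3 is therefore expected at 1900 nM, between 700 nM and 5000 nM, a step of a 1.3-fold lower number from compound 1 to compound 3 (0.11 log units; within the scatter).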

Compound 3, concentration for 50% growth inhibition: 1120 nM
For compound 3 the middle estimate is 1.7-fold (0.23 log units) above the measured one; the range from low to high includes it.
By their numbers in this assay, from the lowest: compounds 3, 2 and 1 (each within the scatter of the next, the first and the last beyond it).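

For the compounds shown here, the urea aryl, a place no earlier step had touched, proves responsive: in this assay, chloro in place of hydrogen, ortho to the trifluoromethyl group, gives a 2.2-fold lower number from compound 1 to compound 3 (0.34 log units; beyond the scatter). This is the only single-place step shown that lies beyond the scatter, although it is modest and rests on one pair. Nothing available accounts for this step.

Going by these compounds, whether fluoro, methyl or an amine at this same place would give a similar step remains open. So does whether chloro here would have the same effect on compound 2.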